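The compounds below may be only part of what the source reports. "The series", "measured", "known", "first", "only" and "open" are said of these compounds alone.

Working notes on the series. Compound 1 `O=C(O)Cc1sc(C(c2ccc(F)cc2)c2ccc(F)cc2)nc1-c1ccoc1` gives 14 nM in an in vitro assay on HEK385-7 cells for displacement of a labelled ligand from prostaglandin D2 receptor 2 (Homo sapiens); on this read-out lower numbers stand for stronger inhibition and higher numbers for weaker inhibition. Within the data shown here, compound 2 `Cc1cc(-c2nc(C(c3ccc(F)cc3)c3ccc(F)cc3)sc2CC(=O)O)ccn1` gives 3.1 nM in this assay, the lowest of the two numbers so far; the only measured step, a 4.5-fold lower number from compound 1 to compound 2 (0.65 log units; beyond the scatter), separates it from compound 1. Compound 3 `O=C(O)Cc1sc(C(c2ccc(F)cc2)c2ccc(F)cc2)nc1-c1ccnc(O)c1` is the next unmeasured member. It differs from compound 2 by hydroxy in place of methyl on an aromatic carbon. Among the measured compounds shown here, no measured pair touches this position: the single step from compound 1 to compound 2 exchanges the whole aromatic group on the core and says nothing about a hydroxy in place of a methyl on the 2-methylpyridin-4-yl ring. For the measured compounds named here, with no guiding step, the working expectation for compound 3 is a number in this assay close to that of compound 2, with a 1.6-fold higher number from compound 2 to compound 3 (0.21 log units; within the scatter) not expected to pass beyond the scatter. Compound 3 is therefore estimated at 5 nM, with a range from 1.5 nM to 20 nM.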

Compound 3, half-maximal inhibitory concentration: 68 nM
Estimate against measurement, compound 3: 14-fold (1.13 log units) below; the measured number lies above the stated range.
By their numbers in this assay, from the lowest: compound 2; then compound 1; then compound 3.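

In this assay, the position next to the ring nitrogen proves sensitive to this exchange: hydroxy in place of methyl gives a 22-fold higher number from compound 2 to compound 3 (1.34 log units; beyond the scatter), so the six-membered aromatic ring with 1 nitrogen does not by itself carry the low number of compound 2. The 2-hydroxypyridin-4-yl group also falls behind furan-3-yl, with a 4.9-fold higher number from compound 1 to compound 3 (0.69 log units; beyond the scatter), so the group on this ring decides whether the exchange from furan-3-yl gains or loses. No measurement at hand accounts for the size of this loss.

The compounds shown leave open where a bare hydrogen at this position would fall, and so whether methyl helps, hydroxy harms, or both. Also open, going by these compounds, is whether methoxy, an amine or chlorine here would stay near compound 2 or follow compound 3.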